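A few compounds are considered here, and "the series" means these few. Any claim that something is new, unique, unknown or untested is made for them only; others in the source may bear on it.

Series notes. In a functional assay on the whole organism with Rattus norvegicus as the target (on this read-out lower numbers stand for an effect already at smaller amounts and higher numbers for an effect only at larger amounts of compound), compound 1 `CC1CCC(=NNc2ccccc2C(=O)O)c2ncc(C(=O)O)c(=O)n21` gives only a limit, > 100 umol/kg; this is the limit of > 100 umol/kg in this assay, at which 1 of the 3 values shown sits. Compound 2 `Cc1cc(C)cc(NN=C2CCC(C)n3c2ncc(C(=O)O)c3=O)c1` likewise gives only a limit in this assay, > 320 umol/kg, which is the limit of > 320 umol/kg in this assay, at which 1 of the 3 values shown sits. Compound 3 `Cc1cc(C)c(NN=C2CCC(C)n3c2ncc(C(=O)O)c3=O)cc1C` gives 320 umol/kg in this assay. Compound 2 therefore stands at a limit and not at a number, as does compound 1. Compound 4 `Cc1cc(NN=C2CCC(C)n3c2ncc(C(=O)O)c3=O)ccc1Br` differs from compound 2 by 4-bromo-3-methylphenyl in place of 3,5-dimethylphenyl on an amine nitrogen. Among the compounds with values here, no step between measured compounds is available in this assay, so the size of this change cannot be read from the series; a step of no more than the usual scatter, in either direction, is expected. For compound 4 a value of 320 umol/kg is estimated, within 100 umol/kg to 1000 umol/kg. The expected step is a number no higher from compound 2 to compound 4 (the limit leaves the size open).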

Compound 4, dose for 50% inhibition: > 100 umol/kg
Compound 4: a limit, no number; the forecaster's own chance of this, stated with the estimate: 60%; the middle value does not contradict the limit.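

Within the data shown here, compound 2 and compound 4 both give only limits in this assay, and no step between them can be read. Left open is whether 4-bromo-3-methylphenyl in place of 3,5-dimethylphenyl on an amine nitrogen changes the read-out in this assay at all.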